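The source may report more compounds than this note shows. Statements on the series, on what has been measured and on what is new or still open speak of the compounds shown alone.

Of the compounds shown here, two have so far been measured in an ADME assay for permeability, using PAMPA, at pH 7.4; a lower number here means that the compound crosses the layer more slowly, a higher number that the compound crosses the layer faster. Compound 1 `CCCCc1nc(=O)c(S(=O)(=O)c2ccc(-c3cccnc3)cc2)c(O)n1-c1c(OC)cccc1OC` gives 6 nm/s, and compound 2 `CCCCc1[nH]c(=O)c(S(=O)(=O)c2ccc(-n3ccccc3=O)cc2)c(O)c1-c1c(OC)cccc1OC` gives 5 nm/s; these two numbers lie within the usual scatter of each other, so no difference between them can be claimed. Compound 3 `CCCCc1nc(=O)c(S(=O)(=O)c2ccc(C)cc2)c(O)n1-c1c(OC)cccc1OC` has not yet been measured. It differs from compound 1 in one place: methyl in place of pyridin-3-yl on an aromatic carbon. Among the compounds with values here, no measured pair shows the effect of this change, so the step is expected to be modest, an upward one of a 1.7-fold higher number from compound 1 to compound 3 (0.22 log units; within the scatter) that sits at the edge of the scatter. Compound 3 is therefore estimated at 10 nm/s, with a range from 4 nm/s to 25 nm/s.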

Compound 3, apparent permeability: 7 nm/s
Estimate against measurement, compound 3: 1.4-fold (0.15 log units) above; low and high end bracket the measured number.
By their numbers in this assay, from the lowest: compounds 2, 1 and 3 (each within the scatter of the next).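

In this assay putting methyl in place of pyridin-3-yl, on an aromatic carbon para to a large group, gives a 1.2-fold higher number from compound 1 to compound 3 (0.07 log units; within the scatter) and so no difference that can be claimed. At this position, then, a whole six-membered aromatic ring can give way to a single carbon without a readable shift in this read-out. Nothing in the available data gives a reason for this outcome. Going by these compounds, whether an amine, a carboxylic acid or a longer chain at this position would also stay within the scatter remains open. So does whether the same change would behave alike on the core of compound 2.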